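Extending the Linker of Compound 2 Toward Compound 4

The source may report more compounds than this note shows. Statements on the series, on what has been measured and on what is new or still open speak of the compounds shown alone.

Of the compounds shown here, three with a shared core have been measured in an ADME assay on L6 cells (Rattus norvegicus) for cytotoxicity, read by resazurin assay, with a stated time of 70 h; a lower number here means a stronger inhibitor, a higher number a weaker inhibitor. Compound 1 `N=C(N)c1ccc2oc(-c3cccc(OCCCCOc4ccccc4)c3)cc2c1` gives 8100 nM in this assay, and compound 3 `c1ccc(OCCCOc2ccc(-c3cc4ccc(C5=NCCN5)cc4o3)cc2)cc1` gives 16800 nM. Compound 2 `CC(C)NC(=N)c1ccc2cc(-c3ccc(OCCCOc4ccccc4)cc3)oc2c1` stands at the top of the set with 49900 nM, a weaker inhibitor than both others; the gap to compound 3 is a 3.0-fold lower number from compound 2 to compound 3 (0.47 log units; beyond the scatter), where an imidazoline-type ring replaces the isopropylamidine, and the gap to compound 1 is larger still, though compound 1 differs from compound 2 in several places at once and no single step can be read from that pair.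

Compound 4 `CC(C)NC(=N)c1ccc2cc(-c3ccc(OCCCCOc4ccccc4)cc3)oc2c1` is the next candidate. Its change from compound 2 is phenoxymethyl in place of phenoxy on a saturated chain carbon, three bonds along the chain from an oxygen on an aromatic ring, so that only the chain linking the two ether oxygens grows by one unit. Among the measured compounds shown here, none of the measured steps concerns this chain length on its own: the step from compound 2 to compound 3 alters the basic head group, and compounds 1 and 3 differ in more than the linker. For the measured compounds named here, with no comparable precedent, the expected step for compound 4 is a 1.1-fold lower number from compound 2 to compound 4 (0.04 log units; within the scatter), essentially none beyond the scatter. Compound 4 is therefore estimated at 45000 nM in this assay, with a range from 20000 nM to 100000 nM.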

Compound 4, half-maximal inhibitory concentration: 15900 nM
Compound 4: middle estimate off by 2.8-fold (0.45 log units), on the high side, and the stated range ends above it.
By their numbers in this assay, from the lowest: compounds 1, 4 and 3 (each within the scatter of the next, the first and the last beyond it); then compound 2.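

In this assay, among the compounds shown here, the single change of phenoxymethyl in place of phenoxy, on a saturated chain carbon, three bonds along the chain from an oxygen on an aromatic ring, gives a 3.1-fold lower number from compound 2 to compound 4 (0.50 log units; beyond the scatter). For the compounds shown here, this is the first reading of the linker length on its own with the isopropylamidine head group held fixed, and it shows that this position is not silent: lengthening the chain alone is enough to move the number by a modest step, whereas the only earlier single-place step, a 3.0-fold lower number from compound 2 to compound 3 (0.47 log units; beyond the scatter), lies in the head group. Nothing in the data shown bears on the reason for this step.

The compounds shown leave open whether the trend continues with a longer chain, such as 2-phenoxyethyl in the same place, or whether it levels off or reverses, since compound 2 and compound 4 give only one step along this chain. They also leave open whether the same lengthening gives a similar step with the five-membered ring head group of compound 3, or when a terminal amine or carboxylic acid takes the place of the phenoxy group.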